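The source may report more compounds than this note shows. Statements on the series, on what has been measured and on what is new or still open speak of the compounds shown alone.

Measured compounds:
compound 1 `CCOC(=O)c1oc2cc(-c3ccc(OC)c(OC)c3)cc(O)c2c1C`: > 4 ug/mL in a functional assay on VA-13 cells (Homo sapiens) for cytotoxicity; a higher number here means that more compound is needed for the effect, a lower number that less compound is needed
compound 2 `CCCOc1ccc(-c2cc(O)c3c(C)c(C(=O)OCC)oc3c2)cc1`: > 4 ug/mL

The value given for compound 1 is a limit of this assay, not a number. The value for compound 2, > 4 ug/mL, is likewise a limit. Compound 2 therefore stands at the limit of > 4 ug/mL in this assay, at which 2 of the 2 values shown sit; no numerical position can be given for it beyond that.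

Compound 3 `CCCCOc1ccc(-c2cc(O)c3c(C)c(C(=O)OCC)oc3c2)cc1` differs from compound 2 by methyl in place of hydrogen on a saturated chain carbon, three bonds along the chain from an oxygen on an aromatic ring. No measured step of this kind exists among these compounds. The expectation for compound 3 rests on compound 2, whose value > 4 ug/mL is only a limit. The step that the limit leaves unreadable from compound 2 to compound 3 is expected to lie within the usual scatter. Compound 3 is estimated at 7 ug/mL, with a range from 3 ug/mL to 25 ug/mL.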

Compound 3, half-maximal effective concentration: > 4 ug/mL
Compound 3 ended at the assay's limit (the forecaster's own chance of this, stated with the estimate: 70%); the middle value is on the limit's open side.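

Compound 2 and compound 3 both stand at a limit rather than a number in this assay, and no step can be read between them: the limit of > 4 ug/mL in this assay, at which 3 of the 3 values shown sit.

The compounds shown leave open how much of any of them is needed for the effect, and whether propyl to butyl alters it.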